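Chloro for bromo on the aryl ring of compound 2

The source may report more compounds than this note shows. Statements on the series, on what has been measured and on what is new or still open speak of the compounds shown alone.

Measured compounds:
compound 1, `CO[C@@]12CCN(C)C[C@H]1[C@H](c1ccc(Br)cc1)C(C#N)=C(N)O2`, 7900 nM
compound 2, `CCN1CC[C@@]2(OC)OC(N)=C(C#N)[C@@H](c3ccc(Br)cc3)[C@@H]2C1`, 13200 nM

Compound 1 and compound 2 share one core and differ only at the ring amine, where compound 2 carries an ethyl group in place of the methyl of compound 1. In a functional assay on trachea (Cavia porcellus) (on this read-out lower numbers stand for stronger inhibition and higher numbers for weaker inhibition), compound 1 gives 7900 nM, and compound 2 gives 13200 nM. Among the measured compounds shown here, the one measured step, a 1.7-fold higher number from compound 1 to compound 2 (0.22 log units; within the scatter), is within the scatter, so the two numbers cannot be ordered. Compound 2 holds the highest of the two numbers, but only by that small margin.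

Compound 3, `CCN1CC[C@@]2(OC)OC(N)=C(C#N)[C@@H](c3ccc(Cl)cc3)[C@@H]2C1`, has not yet been measured. It differs from compound 2 by a single change: chloro in place of bromo on an aromatic carbon. For the measured compounds named here, no measured step touches the aryl halogen; the only step known is the amine change of a 1.7-fold higher number from compound 1 to compound 2 (0.22 log units; within the scatter), which bears on a different position and was small. On the evidence shown, no step beyond the scatter is expected in this assay, with no direction favoured. Compound 3 is therefore estimated to give 16000 nM in this assay, in a range from 6000 nM to 45000 nM. That estimate amounts to an expected 1.2-fold higher number from compound 2 to compound 3 (0.08 log units; within the scatter).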

Compound 3, half-maximal inhibitory concentration: 14900 nM
Compound 3: the middle estimate sits 1.1-fold (0.03 log units) above what was measured; low and high end bracket the measured number.
By their numbers in this assay, from the lowest: compounds 1, 2 and 3 (each within the scatter of the next).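

Among the compounds shown here, replacing 4-bromophenyl with 4-chlorophenyl in this assay gives a 1.1-fold higher number from compound 2 to compound 3 (0.05 log units; within the scatter) and so provides the first reading at the aryl halogen, which the earlier step at the ring amine could not give. At this place, on an aromatic carbon para to a large group, chloro and bromo cannot be told apart with the ethyl group on the ring amine. The aryl halogen thus stands as a second place, after the ring amine, where a single change leaves the number within the scatter, though one exchange between two halogens says little about the position as a whole. No measurement among the data shown accounts for this result.

All three compounds shown carry a halogen at this place, so the compounds leave open what a plain phenyl, a 4-fluorophenyl, a 4-methoxyphenyl or a 4-aminophenyl group would give. Going by these compounds, it also remains open whether chloro and bromo would stay equally close with the methyl group of compound 1 on the ring amine, or with a longer chain such as propyl there.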